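This account rests on a few compounds, and the source may have more. Where it says the series, first, only, none or still open, it means among the compounds named here.

Measured compounds:
Compound 1, `CC(C)Cn1cc(-c2ccnc3[nH]c(C4CCN(CC(=O)N(C)C)CC4)cc23)ccc1=O`, gives 6.6 uL/min.
Compound 2, `COc1cc(F)ccc1-c1ccnc2[nH]c(C3CCN(CC(=O)N(C)C)CC3)cc12`, gives 38 uL/min.
Compound 3, `CC(C)n1cc(-c2ccnc3[nH]c(C4CCN(CC(=O)N(C)C)CC4)cc23)ccc1=O`, gives 2.3 uL/min.

These three compounds share one core and were all tested in an ADME assay on cells (Hepatocyte, Rattus norvegicus) for metabolic stability; a lower number here means slower removal, a higher number faster removal of the compound. Among them compound 3 has the lowest number. The nearest of the other two is reached by the step of a 2.9-fold lower number from compound 1 to compound 3 (0.46 log units; beyond the scatter), the furthest by the step of a 17-fold lower number from compound 2 to compound 3 (1.22 log units; beyond the scatter). Both steps lie beyond the scatter, so compound 3 is the slowest cleared of the three.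

Compound 4, `CCn1cc(-c2ccnc3[nH]c(C4CCN(CC(=O)N(C)C)CC4)cc23)ccc1=O`, has not yet been measured in this assay. It differs from compound 3 in one place: hydrogen in place of methyl on a saturated chain carbon bound to an aromatic nitrogen and a saturated chain carbon. Among the measured compounds shown here, of the measured steps only the one from compound 1 to compound 3 concerns the same part of the molecule, the group on the aromatic nitrogen, and that step was modest. The step from compound 2 to compound 3, which was large, concerns a different position and says little here. The account therefore expects a small step in this assay, perhaps a slightly lower number but likely none beyond the scatter. For compound 4 the estimated value is 2 uL/min, with a range from 0.8 uL/min to 5 uL/min. This estimate corresponds to an expected step of a 1.2-fold lower number from compound 3 to compound 4 (0.06 log units; within the scatter).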

Compound 4, intrinsic clearance in a liver preparation (reported as CLH), per the amount of preparation that the assay uses: < 1 uL/min
Compound 4 gave a limit, no number; the forecaster's own chance of this, stated with the estimate: 15%; middle value at least 2.0-fold (0.30 log units) away from the limit.
By their numbers in this assay, from the lowest: compound 3; then compound 1; then compound 2. At a limit, below all of these: compound 4.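

In this assay compound 4 gives only a limit, < 1 uL/min, and not a number: the limit of < 1 uL/min in this assay, at which 1 of the 4 values shown sits.

Even so, the step from isopropyl to ethyl can be read as a floor, an at least 2.3-fold lower number from compound 3 to compound 4 (0.36 log units; beyond the scatter), so this second trimming of the group on the aromatic nitrogen lowers the number beyond the scatter, as the first did in a 2.9-fold lower number from compound 1 to compound 3 (0.46 log units; beyond the scatter), and no compound shown goes against this order of isobutyl, isopropyl and ethyl. Taken together, the trimming from isobutyl to ethyl gives an at least 6.6-fold lower number from compound 1 to compound 4 (0.81 log units; beyond the scatter), while the exchange of the ring of carbon only in compound 2 for the ring with a hetero atom, now carrying ethyl, gives an at least 38-fold lower number from compound 2 to compound 4 (1.57 log units; beyond the scatter).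

The compounds shown leave open how far the number of compound 4 lies under its limit, so the true size of these steps remains unknown. They also leave open whether a methyl or a cyclopropyl group on the aromatic nitrogen would continue this order, and whether a carboxylic acid in place of the dimethylamide would change the number at all.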